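The compounds below may be only part of what the source reports. "The series", "measured", "known", "first", "only" and "open" are said of these compounds alone.

Working notes on the series. In an assay on HEK293 cells for inhibition of acid ceramidase (Homo sapiens), with a stated time of 10 min (a higher number here means a weaker inhibitor, a lower number a stronger inhibitor), compound 1 `O=C(c1ccccc1)c1ccc2c(c1)oc(=O)n2C(=O)NCCCCc1ccccc1` gives 29 nM, compound 2 `O=C(NCCCCc1ccccc1)n1c(=O)oc2ccc(-c3ccccc3)cc21` gives 42 nM, and compound 3 `COc1ccc(-c2ccc3c(c2)oc(=O)n3C(=O)NCCCCc2ccccc2)cc1` gives 67 nM. Compound 2 stands second highest of the three numbers, and both compound 1 and compound 3 lie within the scatter of it. Going by the values given here, the only step that changes one place, a 2.3-fold higher number from compound 1 to compound 3 (0.36 log units; beyond the scatter), is modest. Compound 4 `O=C(NCCCCc1ccccc1)n1c(=O)oc2ccc([N+](=O)[O-])cc21` differs from compound 2 by nitro in place of phenyl on an aromatic carbon. Among the compounds with values here, no measured step exchanges phenyl for nitro on the shared core, so the narrow spread of the three numbers in this assay is the only guide, and a step of at most modest size is expected. Compound 4 is expected to give 80 nM, in the range 25 nM to 260 nM. The expected step is a 1.9-fold higher number from compound 2 to compound 4 (0.28 log units; within the scatter).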

Compound 4, half-maximal inhibitory concentration: 3 nM
Estimate against measurement, compound 4: 27-fold (1.43 log units) above; the whole stated range lies above it.
By their numbers in this assay, from the lowest: compound 4; then compounds 1, 2 and 3 (each within the scatter of the next, the first and the last beyond it).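

In this assay, going by these compounds alone, the change gives a 14-fold lower number from compound 2 to compound 4 (1.15 log units; beyond the scatter), far more than any difference among the earlier compounds. All of those carried a six-membered aromatic ring of carbon only in their substituent, so this result shows that such a ring is not needed on the shared core for a low number, and that a substituent with no ring and fewer heavy atoms can serve there. Nothing shown gives a cause for the size of this step.

From the compounds shown here alone, whether the step follows from the entry of nitro or from the loss of phenyl stays open. An amine, a nitrile or a methyl on the same aromatic carbon would separate the two.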